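The compounds below may be only part of what the source reports. "The series", "measured", "known", "first", "only" and "open" are said of these compounds alone.

In a functional assay on HeLa cells (Homo sapiens) for antiproliferative activity, read by MTT assay, with a stated time of 48 h (a lower number here means a stronger inhibitor, a higher number a weaker inhibitor), three compounds built on a shared core have been measured. Compound 1 (`C=C(c1cc(OC)c(OC)c(OC)c1)c1ccc(OC)cc1NC(=O)CN(C)C`) stands at 370 nM and compound 2 (`C=C(c1cc(OC)c(OC)c(OC)c1)c1ccc(OC)c(O)c1NC(=O)COC`) at 330 nM while compound 3 (`C=C(c1cc(OC)c(OC)c(OC)c1)c1ccc(OC)c(O)c1NC(=O)COCC`) stands at 690 nM on the same scale. Compound 3 therefore lies within the scatter of compound 1 but beyond the scatter above compound 2. Compound 4 (`C=C(c1cc(OC)c(OC)c(OC)c1)c1ccc(OC)c(O)c1NC(=O)CN(C)C`) carries dimethylamino in place of ethoxy on a saturated chain carbon bound to a carbonyl carbon. Among the compounds with values here, only one measured step touches this side chain: a 2.1-fold higher number from compound 2 to compound 3 (0.32 log units; beyond the scatter) is modest, and it swaps no oxygen for nitrogen, so it bears on the change only indirectly. Within the data shown here, compound 1 already holds the same dimethylamino group at 370 nM but lacks the hydroxy found on compound 4, and no measured pair isolates that hydroxy. A small move toward a lower number is thus expected, and the estimated change is a 1.6-fold lower number from compound 3 to compound 4 (0.22 log units; within the scatter) (an expectation, not beyond the scatter). Compound 4 is therefore estimated at 420 nM (expected range 170 nM to 1000 nM).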

Compound 4, half-maximal inhibitory concentration: 120 nM
The estimate for compound 4 lay 3.5-fold (0.54 log units) above the measured number, outside the stated range (below it).
By their numbers in this assay, from the lowest: compound 4; then compounds 2, 1 and 3 (each within the scatter of the next, the first and the last beyond it).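

With the hydroxy on the shared core kept, dimethylamino on a saturated chain carbon bound to a carbonyl carbon gives a clear gain in this assay over both ether side chains, ethoxy (a 5.8-fold lower number from compound 3 to compound 4 (0.76 log units; beyond the scatter)) and methoxy (a 2.8-fold lower number from compound 2 to compound 4 (0.44 log units; beyond the scatter)), so this position responds to more than the small chain change seen earlier. Within the data shown here, the hydroxy also matters with dimethylamino in place, since hydroxy in place of hydrogen on an aromatic carbon gives a gain of its own (a 3.1-fold lower number from compound 1 to compound 4 (0.49 log units; beyond the scatter)), a change that no earlier pair isolated. No measurement available here explains either gain.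

As far as these compounds go, it remains open whether the hydroxy would count equally with the methoxy or ethoxy side chains. From the compounds shown here alone, it is also open whether a primary amine, a pyrrolidine or a longer chain ending in dimethylamino would keep the gain at this position.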